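The compounds below may be only part of what the source reports. "The series", "measured", "known", "first", "only" and "open" are said of these compounds alone.

Measured so far:
Compound 1 `O=C(NO)c1ccc(N(Cc2ccc(C(F)(F)F)cc2)C(=O)CN(Cc2ccccc2C(F)(F)F)S(=O)(=O)c2ccc(F)c(F)c2)cc1` in an assay on Sf9 cells for inhibition of histone deacetylase 8 (Homo sapiens), read by mobility shift assay (a higher number here means a weaker inhibitor, a lower number a stronger inhibitor), gives > 1000 nM, which is a limit of the assay and not a number.
Compound 2 `O=C(NO)c1ccc(N(Cc2ccc(C(F)(F)F)cc2)C(=O)CN(Cc2ccccc2C(F)(F)F)S(=O)(=O)c2ccc(F)cc2)cc1` in this assay gives > 1000 nM, again only a limit.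
Compound 3 `CC(C)(C)c1ccc(CN(C(=O)CN(Cc2c(F)c(F)c(F)c(F)c2F)S(=O)(=O)c2ccc(F)cc2)c2ccc(C(=O)NO)cc2)cc1` in this assay gives > 1000 nM, again only a limit.

Compound 1 therefore stands at a limit, as do the other two values shown (the limit of > 1000 nM in this assay, at which 3 of the 3 values shown sit). Going by the values given here, the one step between measured compounds, a step that the two limits leave unreadable from compound 1 to compound 2, runs between two limits, so its size cannot be read. Compound 4 `CC(C)(C)c1ccc(CN(C(=O)CN(Cc2ccccc2C(F)(F)F)S(=O)(=O)c2ccc(F)c(F)c2)c2ccc(C(=O)NO)cc2)cc1` differs from compound 1 by tert-butyl in place of trifluoromethyl on an aromatic carbon. Compound 3 already carries the 4-(tert-butyl)benzyl group and also sits at a limit. Among the compounds with values here, no measured step gives a size or direction for this change. Compound 4 is thus expected to stay at the limit, so that a step that the limit leaves unreadable from compound 1 to compound 4 is expected to remain unreadable. The estimate for compound 4 is 3000 nM, within 1000 nM to 20000 nM.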

Compound 4, half-maximal inhibitory concentration: > 1000 nM
Compound 4 ended at the assay's limit; the forecaster's own chance of this, stated with the estimate: 80%; the middle value lies beyond the limit too.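

The step from compound 1 to compound 4 cannot be read, as both compounds sit at a limit and not at a number: the limit of > 1000 nM in this assay, at which 4 of the 4 values shown sit.

The compounds shown leave open the size and direction of the change from trifluoromethyl to tert-butyl.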